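Working notes: phenoxy in place of chloro

The compounds below may be only part of what the source reports. "The series", "measured", "known", "first", "only" and "open" are said of these compounds alone.

In an ADME assay on L1210 cells (Mus musculus) for cytotoxicity, read by cell counting, with a stated time of 2 days (on this read-out lower numbers stand for stronger inhibition and higher numbers for weaker inhibition), compound 1 `O=c1[nH]c(=O)n([C@H]2C[C@H](O)[C@@H](CO)O2)cc1-c1cn(-c2ccccc2)nn1` gives 204000 nM. Among the measured compounds shown here, compound 2 `O=c1[nH]c(=O)n([C@H]2C[C@H](O)[C@@H](CO)O2)cc1-c1cn(-c2ccc(Cl)cc2)nn1` gives 14800 nM, the lower of the two numbers so far. For the measured compounds named here, the only measured step is a 14-fold lower number from compound 1 to compound 2 (1.14 log units; beyond the scatter), which is large and comes with chloro in place of hydrogen on an aromatic carbon.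

Compound 3 `O=c1[nH]c(=O)n([C@H]2C[C@H](O)[C@@H](CO)O2)cc1-c1cn(-c2ccc(Oc3ccccc3)cc2)nn1` has phenoxy in place of chloro on an aromatic carbon. The change lies on a six-membered aromatic ring of carbon only, para to a large group. Going by the values given here, no measured compound carries phenoxy, so the single step of a 14-fold lower number from compound 1 to compound 2 (1.14 log units; beyond the scatter) is the only guide, and it shows just one replacement at this ring. A further move towards a lower number in this assay is expected, smaller than that step, although a result within the scatter of compound 2 cannot be excluded. The estimate means a 3.0-fold lower number from compound 2 to compound 3 (0.47 log units; beyond the scatter). For compound 3 the expected value is 5000 nM, with an estimated range from 1500 nM to 18000 nM.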

Compound 3, half-maximal inhibitory concentration: 500 nM
Estimate against measurement, compound 3: 10-fold (1.00 log units) above, and the stated range ends above it.
By their numbers in this assay, from the lowest: compound 3; then compound 2; then compound 1.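

In this assay the substituent on this aromatic carbon, para to a large group, is not limited to a single atom: phenoxy in place of chloro gives a 30-fold lower number from compound 2 to compound 3 (1.47 log units; beyond the scatter) and so extends the trend that began with a 14-fold lower number from compound 1 to compound 2 (1.14 log units; beyond the scatter) and brings seven heavy atoms, one six-membered aromatic ring and one hydrogen-bond acceptor to the same place. Measured against the unsubstituted ring, phenoxy in place of hydrogen gives a 410-fold lower number from compound 1 to compound 3 (2.61 log units; beyond the scatter), so this one position alone spans the whole range of the three compounds, in the order compound 3, compound 2, compound 1. Nothing available explains what in the phenoxy group produces this result.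

The compounds shown leave open whether the step follows the oxygen link, the second ring or simply the larger size of the group, and whether a still larger group would lower the number further. A directly attached phenyl, a benzyloxy group, a plain methoxy group or an amine at the same carbon would separate these readings, and a carboxylic acid on the outer ring would test how far that ring can be changed.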